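The compounds below may be only part of what the source reports. "The series", "measured", "known", "first", "only" and "open" are said of these compounds alone.

Compound 1 `CCCNCc1cc2c(cc(C(=O)N3CCC(C(=O)NCCC)CC3)n2Cc2ccc(OC)cc2)s1` gives, as a limit of the assay, > 100000 nM.
Compound 2 `CCCNC(=O)C1CCN(C(=O)c2cc3sc(CO)cc3n2Cc2ccc(OC)cc2)CC1` gives 15500 nM.
Compound 3 `CCCNC(=O)C1CCN(C(=O)c2c(CO)c3sccc3n2Cc2ccc(OC)cc2)CC1` gives, again only as a limit, > 100000 nM.

In an ADME assay on HEK-293T cells (Homo sapiens) for cytotoxicity, read by luminescence, with a stated time of 24 h (a higher number here means that more compound is tolerated, a lower number that less compound is tolerated), compound 2 is the only one of the three with a number. Compound 1 reaches a limit of the assay, > 100000 nM. Compound 3 likewise ends at a limit, > 100000 nM. For the measured compounds named here, the one measured step is an at least 6.4-fold higher number from compound 2 to compound 1 (0.80 log units; beyond the scatter), made by the change (propylamino in place of hydroxy on a saturated chain carbon bound to an aromatic carbon). The core of compound 3 and that of compound 2 are built from the same atoms joined differently; the difference between the two cores is not broken down here.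

Compound 4 `CCCNCc1c(C(=O)N2CCC(C(=O)NCCC)CC2)n(Cc2ccc(OC)cc2)c2ccsc12` applies the same change to compound 3: propylamino in place of hydroxy on a saturated chain carbon bound to an aromatic carbon. On the earlier pair this change raised the number beyond the scatter. Compound 3, however, already stands at the limit of > 100000 nM in this assay, at which 2 of the 3 values shown sit, so no rise can show. Compound 4 is therefore expected to stay at that limit, a step that the limit leaves unreadable from compound 3 to compound 4. Compound 4 is estimated at 150000 nM, between 100000 nM and 300000 nM.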

Compound 4, half-maximal cytotoxic concentration: > 100000 nM
Compound 4: a limit, no number; the forecaster's own chance of this, stated with the estimate: 85%; the middle value does not contradict the limit.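

Compound 3 and compound 4 both end at a limit, so no step can be read between them: the limit of > 100000 nM in this assay, at which 3 of the 4 values shown sit.

The compounds shown leave open whether propylamino in place of hydroxy changes the number on the core of compound 3 as it does on the core of compound 2.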